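The source may report more compounds than this note shows. Statements on the series, on what has been measured and on what is new or still open speak of the compounds shown alone.

Measured compounds:
compound 1 `COc1cccc(OS(=O)(=O)c2ccc(N3CCN(C)C3=O)cc2)c1`, 2500 nM
compound 2 `CCN1CCN(c2ccc(S(=O)(=O)Oc3cccc(OC)c3)cc2)C1=O`, 22000 nM

In a functional assay on HT-29 cells (Homo sapiens) for antiproliferative activity, read by sulforhodamine B assay, with a stated time of 48 h (a lower number here means a stronger inhibitor, a higher number a weaker inhibitor), compound 1 gives 2500 nM, while compound 2 gives 22000 nM, the higher of the two numbers. Within the data shown here, the single measured step, an 8.8-fold higher number from compound 1 to compound 2 (0.94 log units; beyond the scatter), replaces a hydrogen on the ring carbon next to the amide-type nitrogen with a methyl group and weakens the inhibitor.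

Compound 3 `CCN1CCN(c2ccc(S(=O)(=O)Oc3ccc(OC)cc3)cc2)C1=O` keeps every atom of compound 2 but joins them differently: 4-methoxyphenyl in place of 3-methoxyphenyl on an oxygen. Among the measured compounds shown here, no measured step touches this part of the molecule, so the one step known, from compound 1 to compound 2, does not bear on it and gives no guide to size or direction. Without any comparable change among the measured compounds, the expected step of no change at the digits printed from compound 2 to compound 3 (within the scatter) is none beyond the scatter, and compound 3 is estimated at 22000 nM, in a range from 7000 nM to 70000 nM that leaves room for a real shift either way.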

Compound 3, half-maximal inhibitory concentration: 60000 nM
Compound 3: the middle estimate sits 2.7-fold (0.44 log units) below what was measured; low and high end bracket the measured number.
By their numbers in this assay, from the lowest: compound 1; then compound 2; then compound 3.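

Replacing 3-methoxyphenyl with 4-methoxyphenyl on an oxygen gives a 2.7-fold higher number from compound 2 to compound 3 (0.44 log units; beyond the scatter) in this assay and so yields a weaker inhibitor. Among these compounds, this is the first measured change at this end of the molecule, and it shows that the number responds to where the methoxy group sits on the ring, even though the two compounds contain the same atoms. Nothing measured here bears on the reason for this shift.

On these data alone, it remains open whether the same change would weaken the inhibitor with the methyl group of compound 1 in place of the ethyl group of compound 2. As far as these compounds go, it is also open how an amine or a carboxylic acid in place of the methoxy group would affect the number.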